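This account rests on a few compounds, and the source may have more. Where it says the series, first, only, none or still open, it means among the compounds named here.

The series shares the alkynyl-substituted bicyclic core seen in compound 1 `Fc1cccc(C#Cc2nc3c(s2)CN(C2CCC2)CC3)c1` and compound 2 `O=C(C1CC12CCC2)N1CCc2nc(C#Cc3ccccc3)sc2C1`. In an assay on HEK293 cells for negative allosteric modulation of metabotropic glutamate receptor 5 (Homo sapiens), read by FLIPR, with a stated time of 1 h (a higher number here means a weaker inhibitor, a lower number a stronger inhibitor), compound 1 gives 200 nM. For compound 2, the same assay yields only a limit, > 10000 nM, so its true potency is not fixed by a number. That limit, (the limit of > 10000 nM in this assay, at which 1 of the 2 values shown sits), marks the weak end of the data shown, and compound 2 therefore stands at the weaker edge, while compound 1 stands clearly inside the measurable range.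

Compound 3 `Cc1nc(C(=O)N2CCc3nc(C#Cc4ccccc4)sc3C2)cs1` is not yet measured. It differs from compound 2 by a group of 6 heavy atoms (4 carbon, 1 nitrogen, 1 sulfur; one five-membered aromatic ring with 2 hetero atoms) in place of a group of 6 heavy atoms (6 carbon; one three-membered non-aromatic ring of carbon only, one four-membered non-aromatic ring of carbon only), on a carbonyl carbon. The change keeps the amide carbonyl and the phenylethynyl arm and swaps only the group on the carbonyl carbon. Within the data shown here, no step between measured compounds corresponds to this exchange, so the size of the expected movement in this assay rests on the change alone. Since compound 2 sits at a limit, any gain can only be inferred as a move toward measurable potency. Compound 3 is expected to land near 3000 nM, within a range of 300 nM to 30000 nM, which corresponds to an expected step of an at least 3.3-fold lower number from compound 2 to compound 3 (0.52 log units; beyond the scatter).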

Compound 3, half-maximal inhibitory concentration: > 10000 nM
Compound 3: no number, only a limit; the forecaster's own chance of this, stated with the estimate: 45%; middle value at least 3.3-fold (0.52 log units) from the limit.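

In this assay compound 3 gives > 10000 nM, which is a limit and not a number. Among these compounds, compound 2 also rests on a limit, so no step from one to the other can be read: the limit of > 10000 nM in this assay, at which 2 of the 3 values shown sit. The compounds shown leave open whether the 2-methyl-1,3-thiazol-4-yl group on the carbonyl carbon changes potency at all relative to the group it replaces.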